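The source may hold more compounds than are shown below. What is called first, only, known or untested is meant among the compounds shown, and "the series" means these compounds.

Working notes on the series. Compound 1 `COc1ccccc1/C=c1\c(=O)[nH]/c(=C/c2ccccc2Cl)c(=O)n1C` is the reference point. In a functional assay on NCI-H1975 cells (Homo sapiens) for cytotoxicity, read by CCK-8 assay, with a stated time of 72 h (on this read-out higher numbers stand for weaker inhibition and lower numbers for stronger inhibition), compound 1 gives 200 nM, the lowest of the two numbers reported so far. Compound 3 `C=CCn1c(=O)/c(=C\c2ccccc2F)[nH]c(=O)/c1=C\c1ccccc1OC` gives 25100 nM in this assay, a gap from compound 1 well beyond the scatter. Compound 2 `C=CCn1c(=O)/c(=C\c2ccc(F)c(Br)c2)[nH]c(=O)/c1=C\c1ccccc1OC` came back as "not active" (no number reported) in this assay, with no number attached. Going by the values given here, compounds 2 and 3 both differ from compound 1 in more than one place, so no single step is drawn from either to compound 1.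

The next compound, compound 4 `COc1ccccc1/C=c1/[nH]c(=O)/c(=C\c2ccccc2OC)n(C)c1=O`, differs from compound 1 in one place: methoxy in place of chloro on an aromatic carbon. The methoxy enters on an aromatic carbon of a six-membered aromatic ring of carbon only, ortho to a large group, so that 2-chlorophenyl becomes 2-methoxyphenyl. Among the compounds with values here, no measured pair carries this single change, so its size is unknown here. The expected step in this assay is a 2.5-fold higher number from compound 1 to compound 4 (0.40 log units; beyond the scatter), a modest loss that may still sit within the scatter. Compound 4 is estimated at 500 nM in this assay, within a range of 100 nM to 3000 nM.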

Compound 4, half-maximal inhibitory concentration: 16900 nM
Estimate against measurement, compound 4: 34-fold (1.53 log units) below; the whole stated range lies below it.
By their numbers in this assay, from the lowest: compound 1; then compounds 4 and 3 (each within the scatter of the next).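

In this assay, going by these compounds alone, methoxy in place of chloro on an aromatic carbon ortho to a large group gives an 85-fold higher number from compound 1 to compound 4 (1.93 log units; beyond the scatter), the first step that can be read at a single place. This position is therefore sensitive to the group it carries, and the low number of compound 1 depends on the chloro here and not on the shared core alone. Nothing available gives a measured reason for the size of this step.

Open, going by these compounds, is how a methyl, a trifluoromethyl or an amine on this aromatic carbon would compare with chloro and methoxy. Equally open, on these data alone, is whether the same change would give a step of similar size on compounds outside this one pair.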